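Carbamate pyrazoles and oral exposure in mouse

A few compounds are considered here, and "the series" means these few. Any claim that something is new, unique, unknown or untested is made for them only; others in the source may bear on it.

Measured compounds:
- compound 1 `CCN1CCN(c2cc(Nc3cc(C)nn3C(=O)C(C)(C)C)nc(N[C@H]3CCN(C(=O)c4ccc(Cl)cc4F)C3)n2)CC1`: 157 ng.h/mL
- compound 2 `CCN1CCN(c2cc(Nc3cc(C)nn3C(=O)OC(C)(C)C)nc(N[C@H]3CCN(C(=O)c4ccc(Cl)cc4F)C3)n2)CC1`: 1130 ng.h/mL

In an ADME assay on the whole organism (Mus musculus, strain ICR) for pharmacokinetics, read by LC-MS, with a stated time of 24 h, at a dose of 10 mg/kg by the oral route (a higher number here means more compound in the circulation at the dose given, a lower number less compound in the circulation), compound 1 gives 157 ng.h/mL, the lower of the two numbers in hand; in this assay compound 2 gives 1130 ng.h/mL. Going by the values given here, the single step in hand is a 7.2-fold higher number from compound 1 to compound 2 (0.86 log units; beyond the scatter).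

Compound 3 `CCOC(=O)n1nc(Nc2cc(N3CCN(CC)CC3)nc(N[C@H]3CCN(C(=O)c4ccc(Cl)cc4F)C3)n2)cc1C` has not been measured in this assay. It differs from compound 1 in one place: 1-(ethoxycarbonyl)-5-methyl-1H-pyrazol-3-yl in place of 3-methyl-1-((tert-butyl)carbonyl)-1H-pyrazol-5-yl on a nitrogen on an aromatic ring. Among the compounds with values here, the one measured step bears on this change, since in both cases a carbonyl bearing a tert-butyl is exchanged for a carbonyl bearing an alkoxy group; the change to compound 3 goes further, in that the alkoxy group is smaller and the pyrazole is joined through a different ring position, for which no measured step exists. Compound 3 is therefore expected to stand higher than compound 1, as a 3.8-fold higher number from compound 1 to compound 3 (0.58 log units; beyond the scatter), with wide uncertainty. The value for compound 3 is estimated at 600 ng.h/mL, in the range 150 ng.h/mL to 2400 ng.h/mL.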

Compound 3, area under the concentration-time curve: 961 ng.h/mL
Compound 3: the middle estimate sits 1.6-fold (0.20 log units) below what was measured, within the range that was stated.
By their numbers in this assay, from the lowest: compound 1; then compounds 3 and 2 (each within the scatter of the next).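

In this assay the exchange of 3-methyl-1-((tert-butyl)carbonyl)-1H-pyrazol-5-yl for 1-(ethoxycarbonyl)-5-methyl-1H-pyrazol-3-yl gives a 6.1-fold higher number from compound 1 to compound 3 (0.79 log units; beyond the scatter). Together with a 7.2-fold higher number from compound 1 to compound 2 (0.86 log units; beyond the scatter), this shows that the rise over compound 1 does not depend on the tert-butoxy group alone, since an ethoxy group on the carbonyl, with the pyrazole joined through a different ring position, also gives a step beyond the scatter. No measurement in hand accounts for either step.

On these data alone, the step to compound 3 changes the alkoxy group and the ring attachment together, so the share of each in the step remains open. Also open, as far as these compounds go, is how a carbonyl bearing an amine such as dimethylamino, in place of the alkoxy group, would stand in this assay.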